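Coumarin-furoxan conjugates in A549 growth inhibition

The compounds below may be only part of what the source reports. "The series", "measured", "known", "first", "only" and "open" are said of these compounds alone.

Measured so far:
- compound 1 `COc1cc2ccc(=O)oc2cc1OCCOc1no[n+]([O-])c1S(=O)(=O)c1ccccc1`: 7240 nM
- compound 2 `COc1cc2ccc(=O)oc2cc1OCCCCOc1no[n+]([O-])c1S(=O)(=O)c1ccccc1`: 6140 nM
- compound 3 `COc1cc2cc(NC(C)=O)c(=O)oc2cc1OCCOc1no[n+]([O-])c1S(=O)(=O)c1ccccc1`: 8790 nM

All three were run in a functional assay on A549 cells (Homo sapiens) for inhibition, read by MTT assay, with a stated time of 48 h; a higher number here means a weaker inhibitor, a lower number a stronger inhibitor. The three numbers sit within the usual scatter of one another, so no ordering among compounds 1, 2 and 3 is claimed. The difference between the core of compound 1 and the core of compound 2 is not broken down here. Compound 3 is derived from compound 1 by acetamido in place of hydrogen on an aromatic carbon and the step of a 1.2-fold higher number from compound 1 to compound 3 (0.08 log units; within the scatter) is within the scatter.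

Compound 4 `COc1cc2cc(NC(C)=O)c(=O)oc2cc1OCCCCOc1no[n+]([O-])c1S(=O)(=O)c1ccccc1` has not yet been measured in this assay. It is derived from compound 2 by acetamido in place of hydrogen on an aromatic carbon which is the same change as from compound 1 to compound 3, at the same place. Because the matched step a 1.2-fold higher number from compound 1 to compound 3 (0.08 log units; within the scatter) stayed within the scatter, the expectation is that the step of a 1.2-fold higher number from compound 2 to compound 4 (0.08 log units; within the scatter) will also stay within the scatter. Within the data shown here, compound 4 is therefore estimated at 7400 nM, with a range from 3700 nM to 15000 nM allowing for the one prior example only.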

Compound 4, half-maximal inhibitory concentration: 7190 nM
For compound 4 the middle estimate is 1.0-fold (0.01 log units) above the measured one; measured number inside the range.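

In this assay, acetamido in place of hydrogen on an aromatic carbon gives a 1.2-fold higher number from compound 2 to compound 4 (0.07 log units; within the scatter), so on the core of compound 2 the change again leaves the number inside the scatter. Set side by side, the two matched steps do not differ: the same change on two cores in this assay, a 1.2-fold higher number (0.08 log units; within the scatter) from compound 1 to compound 3 and a 1.2-fold higher number (0.07 log units; within the scatter) from compound 2 to compound 4, 1.0-fold (0.02 log units) apart, within the scatter of two such steps. This shows that, across these two cores, the change behaves the same way, but since neither step rises out of the scatter, it does not show that acetamido has any effect of its own in this assay, and it does not show that a step of real size would carry from one core to another; two cores in one cell line also say nothing about cores beyond these.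

The compounds shown leave open whether an amine or a carboxylic acid on that same aromatic carbon would give a step beyond the scatter. Among these compounds, they also leave open whether the acetamido step would stay this size with a longer chain than the one in compound 4.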